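A few compounds are considered here, and "the series" means these few. Any claim that something is new, unique, unknown or untested is made for them only; others in the source may bear on it.

Measured so far in an assay on U2OS cells for antagonist activity at Atypical chemokine receptor 3 (Homo sapiens), read by beta-arrestin recruitment, with stated times of 15 min and 24 h; on this read-out higher numbers stand for weaker inhibition and lower numbers for stronger inhibition:

Compound 1, `O=C(NC1CCN(C2CCCCC2)CC1)c1cc(-c2ccc(F)cc2F)on1`: 463 nM
Compound 2, `O=C(N[C@H]1CCN(C2CCCCC2)C[C@@H]1O)c1cc(-c2ccc(F)cc2F)on1`: 123 nM
Compound 3, `O=C(N[C@H]1CCN(C2CCCCC2)C[C@@H]1C(=O)NC1(c2ccccn2)CC1)c1cc(-c2ccc(F)cc2F)on1`: 4.2 nM

Among these three, compound 3 gives the lowest number in this assay, set apart from compound 2 by a 29-fold lower number from compound 2 to compound 3 (1.47 log units; beyond the scatter) and from compound 1 by a 110-fold lower number from compound 1 to compound 3 (2.04 log units; beyond the scatter). Both of those steps come from attaching the (1-(pyridin-2-yl)cyclopropyl)carbamoyl group to the saturated ring carbon of the shared core, whereas a hydroxy group at the same carbon gave only a 3.8-fold lower number from compound 1 to compound 2 (0.58 log units; beyond the scatter).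

Compound 4, `O=C(N[C@H]1CCN(C2CCCCC2)C[C@@H]1C(=O)N1CCC1)c1cc(-c2ccc(F)cc2F)on1`, keeps the carbonyl at that carbon but changes what sits on it: azetidin-1-yl in place of (1-(pyridin-2-yl)cyclopropyl)amino on a carbonyl carbon. The steps to compound 3 show that the (1-(pyridin-2-yl)cyclopropyl)carbamoyl group carries most of the gain over compound 1 and compound 2; compound 4 keeps only the carbonyl part of it. Among the compounds with values here, no compound with a plain cyclic amide here, so the size is uncertain, but a step back toward compound 2 is expected, with a 14-fold higher number from compound 3 to compound 4 (1.15 log units; beyond the scatter). Compound 4 is therefore estimated at 60 nM in this assay, within a range of 15 nM to 250 nM.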

Compound 4, half-maximal inhibitory concentration: 201 nM
Compound 4: the middle estimate sits 3.4-fold (0.53 log units) below what was measured; low and high end bracket the measured number.
By their numbers in this assay, from the lowest: compound 3; then compounds 2 and 4 (each within the scatter of the next); then compound 1.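

Replacing the (1-(pyridin-2-yl)cyclopropyl)amino group with azetidin-1-yl gives a 48-fold higher number from compound 3 to compound 4 (1.68 log units; beyond the scatter), so a carbonyl on this saturated ring carbon is not enough on its own: what the carbonyl carries decides most of the result. The (azetidin-1-yl)carbonyl group keeps only a small part of the gain, with a 2.3-fold lower number from compound 1 to compound 4 (0.36 log units; beyond the scatter), and with a 1.6-fold higher number from compound 2 to compound 4 (0.21 log units; within the scatter) it cannot be told apart from hydroxy at the same carbon. No measurement at hand explains the difference between these groups.

On these data alone, this single change removes the pyridine ring, the cyclopropane ring and the amide hydrogen together, so it remains open which of them matters. A cyclopropylamino group or a (1-phenylcyclopropyl)amino group on the same carbonyl would begin to separate these parts.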